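A few compounds are considered here, and "the series" means these few. Any claim that something is new, unique, unknown or untested is made for them only; others in the source may bear on it.

Among the compounds with values here, in a functional assay on NCI60 cells (Homo sapiens) for inhibition (a higher number here means a weaker inhibitor of growth, a lower number a stronger inhibitor of growth), compound 1 (`O=C1C=CC(O)(c2cc3ccccc3n2S(=O)(=O)c2ccccc2)C=C1`) gives 39 nM, the lowest number among the three compounds measured so far. Compound 2 (`Cc1ccc(S(=O)(=O)n2c(C3(O)C=CC(=O)C=C3)cc3ccccc32)cc1`) gives 110 nM, and compound 3 (`COC(=O)CCc1ccc(S(=O)(=O)n2c(C3(O)C=CC(=O)C=C3)cc3ccccc32)cc1`) gives 680 nM. Compound 4 (`O=C1C=CC(O)(c2cc3ccccc3n2S(=O)(=O)c2ccc(CCC(=O)O)cc2)C=C1`) has not yet been measured. It differs from compound 1 by a single change, 2-carboxyethyl in place of hydrogen on an aromatic carbon, para to a large group.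

Within the data shown here, three measured steps bear on this change. Putting methyl in place of hydrogen on an aromatic carbon gave a 2.8-fold higher number from compound 1 to compound 2 (0.45 log units; beyond the scatter), a modest step. The nearest guide is 2-(methoxycarbonyl)ethyl in place of hydrogen on an aromatic carbon, which gave a 17-fold higher number from compound 1 to compound 3 (1.24 log units; beyond the scatter), a large step. Going from the methyl to that longer chain gave a 6.2-fold higher number from compound 2 to compound 3 (0.79 log units; beyond the scatter), another modest step. In these three compounds, both additions raised the number, and the longer chain raised it more. Among the measured compounds shown here, no measured compound carries 2-carboxyethyl itself, so the guide is only an approximate one.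

A large step towards a higher number is therefore expected in this assay, similar to or somewhat beyond the one seen with the longer chain. The estimated step is a 38-fold higher number from compound 1 to compound 4 (1.59 log units; beyond the scatter). For compound 4 the estimated value is 1500 nM, with an expected range of 400 nM to 5000 nM.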

Compound 4, concentration for 50% growth inhibition: 2340 nM
Compound 4: the middle estimate sits 1.6-fold (0.19 log units) below what was measured, and the stated range covers the measured number.
By their numbers in this assay, from the lowest: compound 1; then compound 2; then compound 3; then compound 4.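

In this assay, 2-carboxyethyl at this position, para to a large group, gives a 60-fold higher number from compound 1 to compound 4 (1.78 log units; beyond the scatter), and the same compound also stands well apart from the methyl compound, with a 21-fold higher number from compound 2 to compound 4 (1.33 log units; beyond the scatter) as the step between them. The new information is that the end of the chain matters as well as its presence, since the chain is the same in both compounds and removing only the methyl of the ester gives a 3.4-fold higher number from compound 3 to compound 4 (0.54 log units; beyond the scatter) as a further rise, beyond the scatter. Across the four compounds the number climbs from hydrogen through methyl and the methyl ester to the acid, no compound goes against that order, and nothing measured here explains it.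

Within the data shown here, every group at this position so far raises the number, so it remains open whether any group could leave it near that of compound 1 or lower it, for instance a fluorine or a hydroxyl. Also open, from the compounds shown here alone, is how an amine or a primary amide at the end of the same chain would compare, and whether a carboxylic acid on a shorter or longer chain would give a smaller or larger rise.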